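The compounds below may be only part of what the source reports. "The series", "measured", "known", "first", "only" and "open" are said of these compounds alone.

Measured compounds:
- compound 1 `CN(C)c1ccc(/C=C/C(=O)c2ccc(O)cc2O)cc1`; in an assay on cells for inhibition of Amine oxidase [flavin-containing] B (Homo sapiens), read by fluorescence, with a stated time of 30 min (on this read-out higher numbers stand for weaker inhibition and lower numbers for stronger inhibition), compound 1 gives 310 nM
- compound 2 `CN(C)c1ccc(/C=C/C(=O)c2ccc(OC(=O)N3CCCC3)cc2O)cc1`; in this assay compound 2 gives 290 nM
- compound 3 `CCN(CC)c1ccc(/C=C/C(=O)c2ccc(OC(=O)N3CCCC3)cc2O)cc1`; in this assay compound 3 gives 6700 nM

Compound 3 stands highest of the three numbers in this assay: the step of a 23-fold higher number from compound 2 to compound 3 (1.36 log units; beyond the scatter) is large and beyond the scatter, and against compound 1 the gap is of the same size, so compound 3 is the weakest inhibitor shown. The step of a 1.1-fold lower number from compound 1 to compound 2 (0.03 log units; within the scatter) is within the scatter.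

Compound 4 `O=C(/C=C/c1ccc(N2CCCC2)cc1)c1ccc(OC(=O)N2CCCC2)cc1O` differs from compound 3 as follows: pyrrolidin-1-yl in place of diethylamino on an aromatic carbon. Going by the values given here, no measured step covers this exchange. Among the compounds with values here, the only step bearing on this position is a 23-fold higher number from compound 2 to compound 3 (1.36 log units; beyond the scatter), a large loss on going from dimethylamino to diethylamino; pyrrolidin-1-yl matches diethylamino in count but closes it into a ring, so a number between the two measured extremes is expected rather than a reversal of the whole loss. The expected step is a 4.5-fold lower number from compound 3 to compound 4 (0.65 log units; beyond the scatter), toward stronger inhibition but with wide uncertainty. For compound 4 the estimate in this assay is 1500 nM, with a range from 300 nM to 8000 nM.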

Compound 4, half-maximal inhibitory concentration: 710 nM
Beside the measured number, compound 4's estimate is 2.1-fold (0.32 log units) above it; the range from low to high includes it.
By their numbers in this assay, from the lowest: compounds 2 and 1 (each within the scatter of the next); then compound 4; then compound 3.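

In this assay, closing diethylamino into pyrrolidin-1-yl, with the same count of heavy atoms, gives a 9.4-fold lower number from compound 3 to compound 4 (0.97 log units; beyond the scatter) on the same aromatic carbon, so the heavy-atom count of the group does not by itself set the number here. Dimethylamino still keeps the lower number on the shared core, with a 2.4-fold higher number from compound 2 to compound 4 (0.39 log units; beyond the scatter) for the change to the ring, so the ring recovers only part of the loss seen with diethylamino. No available evidence accounts for the gap between the open chain and the ring.

Going by these compounds, it remains open how a six-membered ring such as piperidin-1-yl or morpholin-4-yl, or a smaller methylamino or free amino group, would read at this position. On these data alone, it is also open whether pyrrolidin-1-yl behaves the same way on the core of compound 1, which carries a free hydroxyl group in place of the carbamate.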